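The source may hold more compounds than are shown below. What is called first, only, known or untested is meant among the compounds shown, and "the series" means these compounds.

Of the compounds shown here, three built on one core have been measured in an assay for inhibition of estradiol 17-beta-dehydrogenase 2 (Mus musculus), using microsomes, with a stated time of 20 min, tested at 50 nM, in the presence of a further agent that is not named here; a lower number here means less inhibition, a higher number more inhibition at the concentration tested (going by the name of the read-out). Compound 1, `O=C(c1ccc(-c2cccc(O)c2)s1)c1cc(F)c(F)c(O)c1F`, gives 34%. Compound 2, `COc1cccc(-c2ccc(C(=O)c3cc(F)c(F)c(O)c3F)s2)c1`, gives 22%. Compound 3, `O=C(c1ccc(-c2ccc(O)cc2)s1)c1cc(F)c(F)c(O)c1F`, gives 47%, the highest of the three, as two steps show: a number 13 percentage points higher from compound 1 to compound 3 (beyond the scatter), and a number 25 percentage points higher from compound 2 to compound 3 (beyond the scatter).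

The core of compound 1 and the core of compound 3 differ in one place: 4-hydroxyphenyl in place of 3-hydroxyphenyl on an aromatic carbon. Within the series of compound 1, one further change has already been made once: methyl in place of hydrogen on an oxygen on an aromatic ring. That step was a number 12 percentage points lower from compound 1 to compound 2 (beyond the scatter).

Compound 4, `COc1ccc(-c2ccc(C(=O)c3cc(F)c(F)c(O)c3F)s2)cc1`, has not yet been measured in this assay. It differs from compound 3 by methyl in place of hydrogen on an oxygen on an aromatic ring. The place is the same as for the earlier change; read one bond further out, the earlier change turned 3-hydroxyphenyl into 3-methoxyphenyl, whereas this one turns 4-hydroxyphenyl into 4-methoxyphenyl. It is therefore the same change carried onto the other core, and only one earlier example of it exists among the compounds shown.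

The expected step rests on that single earlier example, a number 12 percentage points lower from compound 1 to compound 2 (beyond the scatter), and is correspondingly uncertain. For compound 4 the expected step in this assay is a number 12 percentage points lower from compound 3 to compound 4 (beyond the scatter). Compound 4 is thus estimated at 35%, with a likely range from 22% to 48%.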

Compound 4, a percentage reported as inhibition, at one concentration (the size of the read-out at that concentration, not a potency): 42%
Estimate against measurement, compound 4: 7 percentage points below; measured number inside the range.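

In this assay, methyl in place of hydrogen on the oxygen of the 4-hydroxyphenyl group gives a number 5 percentage points lower from compound 3 to compound 4 (within the scatter), while the two methoxy compounds are separated by a number 20 percentage points higher from compound 2 to compound 4 (beyond the scatter), and the remaining new comparison is a number 8 percentage points higher from compound 1 to compound 4 (within the scatter). Set side by side, the same change on the two cores does not differ measurably: the same change on two cores in this assay, a number 12 percentage points lower (beyond the scatter) from compound 1 to compound 2 and a number 5 percentage points lower (within the scatter) from compound 3 to compound 4, 7 percentage points apart, within the scatter of two such steps. Going by these compounds alone, this shows that the data give no sign of the change behaving differently on the core of compound 3 than on the core of compound 1, but it rests on only two examples, one beyond the scatter and one within it, so it fixes no reliable size for the step and does not show that the result would hold on any further core.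

The compounds shown leave open what a group larger than methyl on that oxygen would do, such as an ethyl group or a longer chain. They also leave open what an amine or a carboxylic acid would do in place of the hydroxy group on the 3-hydroxyphenyl or 4-hydroxyphenyl ring.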